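A few compounds are considered here, and "the series" means these few. Any claim that something is new, unique, unknown or untested is made for them only; others in the source may bear on it.

Measured in an ADME assay on the whole organism (Rattus norvegicus, strain Sprague-Dawley) for pharmacokinetics, using cassette dosing, at a dose of 1 mg/kg by the oral route; a lower number here means that a smaller share of the oral dose reaches the circulation, a higher number that a larger share of the oral dose reaches the circulation:
Compound 1 `O=C(Nc1ccc2[nH]c(=O)oc2c1)C(=O)N1CCN(c2ccc(Cl)c(F)c2)CC1`: 28.2%
Compound 2 `C[C@@H]1CN(c2ccc(F)c(F)c2)CCN1C(=O)C(=O)Nc1ccc2[nH]c(=O)oc2c1`: 118%

In this assay, compound 2 stands highest of the two at 118%, beyond the scatter from compound 1. The next structure, compound 3 `C[C@@H]1CN(c2ccc(Cl)c(F)c2)CCN1C(=O)C(=O)Nc1ccc2[nH]c(=O)oc2c1`, has chloro in place of fluoro on an aromatic carbon, ortho to a fluoro group and para to a large group: chloro in place of fluoro on an aromatic carbon. For the measured compounds named here, the only other measured compound, compound 1, gives 28.2%, so a fall is expected rather than a rise. The expected change is a number 53 percentage points lower from compound 2 to compound 3 (beyond the scatter), a downward step beyond the scatter. For compound 3 the estimated value is 65%, with an expected range of 30% to 105%.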

Compound 3, oral bioavailability: 30.4%
Compound 3: the middle estimate sits 34.6 percentage points above what was measured, within the range that was stated.
By their numbers in this assay, from the lowest: compounds 1 and 3 (each within the scatter of the next); then compound 2.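

Within this assay, chloro in place of fluoro on the aromatic carbon para to a large group is a large change when the ring methyl is present: a number 87.6 percentage points lower from compound 2 to compound 3 (beyond the scatter). With chloro at this position, methyl in place of hydrogen on the saturated ring carbon gives a number 2.2 percentage points higher from compound 1 to compound 3 (within the scatter), so the methyl alone brings no gain beyond the scatter in this pair. Nothing available here accounts for the step. The compounds shown leave open how a 3,4-difluorophenyl compound without the methyl would read, and whether a nitrile or a methoxy group on this aromatic carbon would stand nearer compound 2 or compound 3.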